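Methoxy for fluorine on the aryl group of compound 1

A few compounds are considered here, and "the series" means these few. Any claim that something is new, unique, unknown or untested is made for them only; others in the source may bear on it.

Among the measured compounds shown here, compound 1 `CC1(C)[C@H]2CC[C@]1(C)N(Cc1cn(-c3ccc(F)cc3)nn1)C(=O)C2` gives 230 nM in a functional assay on A549 cells (Homo sapiens) for inhibition, read by MTT assay, with a stated time of 24 h (on this read-out lower numbers stand for stronger inhibition and higher numbers for weaker inhibition), the highest of the three numbers measured so far. Compound 2 `CC1(C)[C@H]2CC[C@]1(C)N(Cc1cn(-c3ccc(Br)cc3)nn1)C(=O)C2` gives 80 nM, and compound 3 `CC1(C)[C@H]2CC[C@]1(C)N(Cc1cn(-c3cccc(O)c3)nn1)C(=O)C2` gives 180 nM. The step from compound 1 to compound 2 is a 2.9-fold lower number from compound 1 to compound 2 (0.46 log units; beyond the scatter), the step from compound 1 to compound 3 is a 1.3-fold lower number from compound 1 to compound 3 (0.11 log units; within the scatter), and between compound 2 and compound 3 the step is a 2.3-fold higher number from compound 2 to compound 3 (0.35 log units; beyond the scatter).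

Compound 4 `COc1ccc(-n2cc(CN3C(=O)C[C@@H]4CC[C@@]3(C)C4(C)C)nn2)cc1` differs from compound 1 by methoxy in place of fluoro on an aromatic carbon. For the measured compounds named here, the only measured step at the same aromatic carbon is a 2.9-fold lower number from compound 1 to compound 2 (0.46 log units; beyond the scatter), a modest gain; the step of a 1.3-fold lower number from compound 1 to compound 3 (0.11 log units; within the scatter) touches a different place and stays within the scatter. Neither step is the change made in compound 4, so only a weak lean towards a lower number can be read from them. Compound 4 is therefore expected to give about 150 nM, with a range from 60 nM to 400 nM. The expected step is a 1.5-fold lower number from compound 1 to compound 4 (0.19 log units; within the scatter), which may well stay inside the scatter.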

Compound 4, half-maximal inhibitory concentration: 50 nM
For compound 4 the middle estimate is 3.0-fold (0.48 log units) above the measured one; measured number below the stated range.
By their numbers in this assay, from the lowest: compounds 4 and 2 (each within the scatter of the next); then compounds 3 and 1 (each within the scatter of the next).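

In this assay, methoxy in place of fluoro gives a 4.6-fold lower number from compound 1 to compound 4 (0.66 log units; beyond the scatter) at the same aromatic carbon where bromo gave a 2.9-fold lower number from compound 1 to compound 2 (0.46 log units; beyond the scatter), so two different groups at this carbon now lower the number beyond the scatter. Methoxy in place of bromo gives a 1.6-fold lower number from compound 2 to compound 4 (0.20 log units; within the scatter), which leaves those two groups indistinguishable here, while both stand apart from fluoro. The step of a 3.6-fold lower number from compound 3 to compound 4 (0.56 log units; beyond the scatter) shows that an oxygen-bearing group on the aryl ring does not alone give the low number, as compound 3 goes against that reading, although its group differs from that of compound 4 in both kind and place.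

Nothing shown here gives a measured reason for these differences. Going by these compounds, it remains open whether an amine, a carboxylic acid or a longer alkoxy chain such as ethoxy at this aromatic carbon would keep the number as low.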